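Urea aryl exchange in a pyrazole series

A few compounds are considered here, and "the series" means these few. Any claim that something is new, unique, unknown or untested is made for them only; others in the source may bear on it.

Measured so far:
- compound 1 `O=C(Nc1cccc(-n2cc(-c3ccncc3)c(-c3ccc(Cl)c(O)c3)n2)c1)Nc1ccc(Cl)c(Cl)c1`: 1100 nM in a functional assay on MDA-MB-435 cells (Homo sapiens) for inhibition, read by sulforhodamine B assay, with a stated time of 48 h; on this read-out higher numbers stand for weaker inhibition and lower numbers for stronger inhibition
- compound 2 `COc1cc(-c2nn(-c3cccc(NC(=O)c4cccc(C(F)(F)F)c4)c3)cc2-c2ccncc2)ccc1Cl`: 710 nM in this assay

Going by the values given here, only two numbers exist in this assay. Compound 1 gives the higher of the two, but the gap to compound 2 is within the scatter, so the two compounds cannot be placed in order on these data. Among the compounds with values here, no pair of compounds differing in a single place has been measured, so no measured step is available to anchor an expectation.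

Compound 3 `O=C(Nc1cccc(-n2cc(-c3ccncc3)c(-c3ccc(Cl)c(O)c3)n2)c1)Nc1ccc(Cl)c(C(F)(F)F)c1` is not yet measured. It differs from compound 1 as follows: trifluoromethyl in place of chloro on an aromatic carbon

Within the data shown here, with no measured step to lean on, the expectation for the step from compound 1 to compound 3 rests on the change alone. A modest gain in inhibition is expected, a 1.8-fold lower number from compound 1 to compound 3 (0.26 log units; within the scatter), though a result within the scatter would not be surprising. Compound 3 is therefore estimated at 600 nM in this assay, with a range from 250 nM to 1500 nM.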

Compound 3, half-maximal inhibitory concentration: 660 nM
Estimate against measurement, compound 3: 1.1-fold (0.04 log units) below, within the range that was stated.
By their numbers in this assay, from the lowest: compounds 3, 2 and 1 (each within the scatter of the next).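

Going by these compounds alone, the exchange of 3,4-dichlorophenyl for 4-chloro-3-(trifluoromethyl)phenyl on the urea gives the first single-place step: in this assay it reads a 1.7-fold lower number from compound 1 to compound 3 (0.22 log units; within the scatter) and so stays within the scatter. At this aromatic carbon, ortho to a chloro group and meta to a large group, 4 heavy atoms can therefore stand in place of 1 with no change that these data can resolve. No measurement available here explains the size of this step.

From the compounds shown here alone, one step at one position cannot show how far this carbon tolerates other groups, so it remains open whether an amine, a carboxylic acid or a longer alkyl chain here would give a step beyond the scatter. Also open, going by these compounds, is whether the chloro group that stays on this ring contributes to inhibition.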